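The source may hold more compounds than are shown below. What is called first, only, known or untested is meant among the compounds shown, and "the series" means these compounds.

Compound 1 `COc1ccc(CN(C(=O)C2CC2)c2cc(OC)c(OC)c(OC)c2)cc1O` is the stronger of the two measured compounds in a functional assay on HCT-116 cells (Homo sapiens) for inhibition, read by MTT assay, with a stated time of 48 h (a higher number here means a weaker inhibitor, a lower number a stronger inhibitor), where compound 1 gives 49 nM. Going by the values given here, the only other measured compound, compound 2 `C/C=C/C(=O)N(Cc1ccc(OC)c(C)c1)c1cc(OC)c(OC)c(OC)c1`, carries a different amide acyl group and a different benzyl substitution pattern; in this assay compound 3 is not yet known, but compound 2 gives 23500 nM, a gap from compound 1 that lies well beyond the scatter. Since compound 2 differs from compound 1 in more than one place, the two values say nothing on their own about which change carries the loss.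

Compound 3 `COc1ccc(CN(C(C)=O)c2cc(OC)c(OC)c(OC)c2)cc1O` departs from compound 1 in a single place: the acyl group on the amide nitrogen is changed from cyclopropylcarbonyl to acetyl (methyl in place of cyclopropyl on a carbonyl carbon). Among the compounds with values here, no measured pair in this set isolates this kind of change, so the expectation rests on the general closeness of the two groups. A small upward step toward weaker inhibition is expected, within or just past the scatter, and the step is estimated as a 2.2-fold higher number from compound 1 to compound 3 (0.35 log units; beyond the scatter). Compound 3 is therefore expected to give 110 nM, with a range from 30 nM to 450 nM.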

Compound 3, half-maximal inhibitory concentration: 270 nM
Beside the measured number, compound 3's estimate is 2.5-fold (0.39 log units) below it; low and high end bracket the measured number.
By their numbers in this assay, from the lowest: compound 1; then compound 3; then compound 2.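

The acyl group on the amide nitrogen now has a reading of its own in this assay: with methyl in place of cyclopropyl on a carbonyl carbon and the rest of the structure unchanged, the result is a 5.5-fold higher number from compound 1 to compound 3 (0.74 log units; beyond the scatter). This position is therefore not indifferent to the group it carries, and of the two groups compared here, cyclopropyl goes with the lower number. No available evidence bears on what lies behind this step.

From the compounds shown here alone, with only cyclopropyl and methyl to compare at this position, it remains open whether the ring itself matters or simply the number of carbons, a question that ethyl, isopropyl or cyclobutyl on the same carbonyl carbon would help to separate. Going by these compounds, the contribution of the other parts of the structure also remains open, including the hydroxyl group on the benzyl ring of compound 1, since compound 2 differs from compound 1 in more than one place and cannot isolate any of them.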